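This account rests on a few compounds, and the source may have more. Where it says the series, first, only, none or still open, it means among the compounds named here.

Measured so far:
- Compound 1 `O=C(N/N=C1\C[C@@H](c2ccc(O)cc2)Oc2cc(O)cc(O)c21)c1cccs1`: >= 11300 nM (a limit)
- Compound 2 `COc1cc(O)c2c(c1)O[C@H](c1ccc(O)cc1)C/C2=N\Nc1ccc(Br)cn1`: 4300 nM

For the measured compounds named here, in a functional assay on L5178Y cells (Mus musculus) for inhibition, read by MTT assay, with a stated time of 24 h (on this read-out higher numbers stand for weaker inhibition and lower numbers for stronger inhibition), compound 2 gives 4300 nM, the only true number available so far, so it can serve as the starting point but cannot yet be ranked against another number. For compound 1, the result of >= 11300 nM is a limit of the assay and not a number.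

The next compound, compound 3 `COc1cc(O)c2c(c1)O[C@H](c1ccc(O)cc1)C/C2=N\NC(=O)c1cccs1`, has not yet been measured. It differs from compound 2 in one place: (thiophen-2-yl)carbonyl in place of 5-bromopyridin-2-yl on an amine nitrogen. In words, (thiophen-2-yl)carbonyl stands in place of 5-bromopyridin-2-yl on an amine nitrogen.

Going by the values given here, no measured pair shows this change directly, so any forecast is uncertain. Among the compounds with values here, the only hint is that compound 1, the one measured compound carrying (thiophen-2-yl)carbonyl, gave the limit of >= 11300 nM. A moderate loss of inhibition is therefore expected. The estimated change is a 2.1-fold higher number from compound 2 to compound 3 (0.32 log units; beyond the scatter), in the direction of weaker inhibition in this assay. The expected value for compound 3 is 9000 nM, with an estimated range from 3500 nM to 23000 nM.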

Compound 3, half-maximal inhibitory concentration: 9400 nM
For compound 3 the middle estimate is 1.0-fold (0.02 log units) below the measured one; the measured number falls inside the stated range.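

In this assay, for the compounds shown here, (thiophen-2-yl)carbonyl in place of 5-bromopyridin-2-yl on an amine nitrogen gives a 2.2-fold higher number from compound 2 to compound 3 (0.34 log units; beyond the scatter), a modest loss of inhibition and the first true number for a compound carrying this group. The two groups have the same count of heavy atoms, so this step does not trade a larger group for a smaller one; it trades a six-membered aromatic ring bearing bromine for a five-membered aromatic ring attached through a carbonyl. The other new step, methyl in place of hydrogen on an oxygen on an aromatic ring, gives an at least 1.2-fold lower number from compound 1 to compound 3 (0.07 log units; that floor lies within the scatter). That floor does not fix the size of the step, because compound 1 gives only a limit: the limit of >= 11300 nM in this assay, at which 1 of the 3 values shown sits.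

With a single swap, the ring and the carbonyl change together, so the step cannot show which of them accounts for the loss. On these data alone, a (5-bromopyridin-2-yl)carbonyl group or a plain pyridin-2-yl group on the same nitrogen would begin to separate the carbonyl, the ring and the bromine, and it remains open whether any of these would restore inhibition.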